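The compounds below may be only part of what the source reports. "The series", "measured", "known", "first", "only" and "open" are said of these compounds alone.

Compound 2 `CN(c1ccc([N+](=O)[O-])cc1OC1CCCCC1)S(C)(=O)=O` gives 470 nM in an assay on SK-BR-3 cells for inhibition of Aromatase (Homo sapiens); a higher number here means a weaker inhibitor, a lower number a stronger inhibitor. Compound 1 `CS(=O)(=O)Nc1ccc([N+](=O)[O-])cc1OC1CCCC1` gives 870 nM in this assay, and these two values lie within the scatter of each other, so neither compound can be placed ahead of the other. Compound 3 `CCCCCCOc1cc([N+](=O)[O-])ccc1N(C)S(C)(=O)=O` differs from compound 2 in one place: hexyl in place of cyclohexyl on an oxygen on an aromatic ring. Going by the values given here, no measured pair shows this change, so its size is unknown from the data. Compound 3 is expected to give 600 nM in this assay, with a range from 250 nM to 1500 nM. This estimate means an expected step of a 1.3-fold higher number from compound 2 to compound 3 (0.11 log units; within the scatter), not beyond the scatter.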

Compound 3, half-maximal inhibitory concentration: 4490 nM
Beside the measured number, compound 3's estimate is 7.5-fold (0.87 log units) below it; measured number above the stated range.
By their numbers in this assay, from the lowest: compounds 2 and 1 (each within the scatter of the next); then compound 3.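

Exchanging cyclohexyl for hexyl on an oxygen on an aromatic ring leaves the heavy-atom count unchanged, yet brings a 9.6-fold higher number from compound 2 to compound 3 (0.98 log units; beyond the scatter) in this assay, so for this pair the ring itself matters and not the carbon count alone. Compounds 1 and 2 differ in more than one place and could not show this. Nothing measured here accounts for the step. On these data alone, whether a shorter chain such as butyl, or a branched one such as isopropyl, would stay close to compound 2 remains open. So does the effect of an amine at the end of the hexyl chain of compound 3.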